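This account rests on a few compounds, and the source may have more. Where it says the series, first, only, none or still open, it means among the compounds named here.

Compound 1 `CO/N=C(/COc1c(-c2ccccc2)oc2ccccc2c1=O)c1ccc(F)cc1` gives 13000000 nM in a functional assay on SK-HEP1 cells (Homo sapiens) for antiproliferative activity; a higher number here means a weaker inhibitor of growth, a lower number a stronger inhibitor of growth. Compound 2 `CO/N=C(/COc1c(-c2ccccc2)oc2ccccc2c1=O)c1ccc(OC)cc1` differs from it by methoxy in place of fluoro on an aromatic carbon and gives 11000000 nM; the step is a 1.2-fold lower number from compound 1 to compound 2 (0.07 log units; within the scatter). Compound 3 `CO/N=C(/COc1ccc2oc(-c3ccccc3)cc(=O)c2c1)c1ccc(F)cc1` holds the same atoms as compound 1 joined differently; the difference between the two cores is not broken down here. In this assay compound 3 gives 7910000 nM, within the scatter of compound 2 and of compound 1. Compound 4 `CO/N=C(/COc1ccc2oc(-c3ccccc3)cc(=O)c2c1)c1ccc(OC)cc1` is not yet measured; it differs from compound 3 by methoxy in place of fluoro on an aromatic carbon, the same change as from compound 1 to compound 2, at the same place. In this assay the step is expected to be a 1.2-fold lower number from compound 3 to compound 4 (0.08 log units; within the scatter), resting on the step of a 1.2-fold lower number from compound 1 to compound 2 (0.07 log units; within the scatter) seen for the same change on the core of compound 1. Compound 4 is therefore estimated at 6600000 nM, between 3000000 nM and 14000000 nM.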

Compound 4, concentration for 50% growth inhibition: 2000000 nM
Compound 4: middle estimate off by 3.3-fold (0.52 log units), on the high side; measured number below the stated range.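

In this assay, methoxy in place of fluoro gives a 4.0-fold lower number from compound 3 to compound 4 (0.60 log units; beyond the scatter), and the change does not carry over at the same size from one core to the other: the same change on two cores in this assay, a 1.2-fold lower number (0.07 log units; within the scatter) from compound 1 to compound 2 and a 4.0-fold lower number (0.60 log units; beyond the scatter) from compound 3 to compound 4, 3.3-fold (0.52 log units) apart, beyond the scatter of two such steps

In these two pairs, then, the size of the step depends on the core, and a step read on the core of compound 1 does not transfer reliably to the core of compound 3. The pairs do not show which feature of the cores sets the gap, and they give no rule for other cores or other groups.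

From the compounds shown here alone, it remains open whether the larger step on the core of compound 3 is particular to methoxy or also appears with an amine or a carboxylic acid in place of fluoro. A longer chain in place of methoxy is equally untested among the compounds shown.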